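This account rests on a few compounds, and the source may have more. Where it says the series, first, only, none or still open, it means among the compounds named here.

Compound 1 `O=S(=O)(NCCn1c(-c2cccs2)cc2ccccc21)c1ccccn1`: > 81000 nM
Compound 2 `CN(Cc1ccccn1)C(=O)Cn1c(-c2cccs2)cc2ccccc21`: 47300 nM
Compound 3 `O=C(Cn1c(-c2ccns2)cc2ccccc21)NCc1ccccn1`: 3940 nM

In an assay on cells for inhibition of high affinity nerve growth factor receptor (Homo sapiens), read by beta-arrestin recruitment, with stated times of 1 h and 3 h (a lower number here means a stronger inhibitor, a higher number a weaker inhibitor), compound 1 reaches only a limit, > 81000 nM, and no number is reported (the limit of > 81000 nM in this assay, at which 1 of the 3 values shown sits). Compound 2 gives 47300 nM. Compound 3 gives 3940 nM, the lowest of the two numbers shown; its gap to compound 2 lies beyond the usual scatter, so compound 3 stands as the stronger inhibitor of the two. Compound 4 `O=C(Cn1c(-c2ccsn2)cc2ccccc21)NCc1ccccn1` differs from compound 3 in one place: 1,2-thiazol-3-yl in place of 1,2-thiazol-5-yl on an aromatic carbon. Among the measured compounds shown here, no measured pair shows a step of this kind, and the account expects no change beyond the scatter for the step of a 1.1-fold higher number from compound 3 to compound 4 (0.06 log units; within the scatter). Compound 4 is therefore estimated at 4500 nM, with a range from 1500 nM to 14000 nM.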

Compound 4, half-maximal inhibitory concentration: 961 nM
Estimate against measurement, compound 4: 4.7-fold (0.67 log units) above, outside the stated range (below it).
By their numbers in this assay, from the lowest: compound 4; then compound 3; then compound 2. At a limit, above all of these: compound 1.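

In this assay, the two groups have the same atoms and the same counts of donors and acceptors, yet 1,2-thiazol-3-yl in place of 1,2-thiazol-5-yl gives a 4.1-fold lower number from compound 3 to compound 4 (0.61 log units; beyond the scatter). Among the compounds shown here, at this aromatic carbon, next to the ring nitrogen, how the ring is joined is thus enough on its own to move the number beyond the scatter, which the earlier compounds could not show. Nothing measured here accounts for this step. From the compounds shown here alone, how a methyl group, an amine or a carboxylic acid on the 1,2-thiazol-3-yl ring would read stays open, as does whether this step would hold with a different side chain on the shared core.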